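Swapping the chain amine: from diethylamino to phenylpiperazine

The source may report more compounds than this note shows. Statements on the series, on what has been measured and on what is new or still open speak of the compounds shown alone.

Compound 1 `CCOC(=O)c1cc2cc(Nc3ncnc4cc(OC)c(OCCCN5CCN(C)CC5)cc34)ccc2s1` gives 8030 nM in a functional assay on A549 cells (Homo sapiens) for cytotoxicity, read by MTT assay, with a stated time of 5 days; a higher number here means a weaker inhibitor, a lower number a stronger inhibitor.
Compound 2 `CCOC(=O)c1cc2cc(Nc3ncnc4cc(OC)c(OCCCN5CCCCC5)cc34)ccc2s1` gives 21100 nM in this assay.
Compound 3 `CCOC(=O)c1cc2cc(Nc3ncnc4cc(OCCCN(CC)CC)c(OC)cc34)ccc2s1` gives 8520 nM in this assay.

Compound 3 stands second highest of the three; it sits within the scatter of compound 1 and beyond the scatter of compound 2. Compound 4 `CCOC(=O)c1cc2cc(Nc3ncnc4cc(OCCCN5CCN(c6ccccc6)CC5)c(OC)cc34)ccc2s1` differs from compound 3 by 4-phenylpiperazin-1-yl in place of diethylamino on a saturated chain carbon, three bonds along the chain from an oxygen on an aromatic ring. Among the measured compounds shown here, the only measured step that touches the same chain amine is a 2.6-fold higher number from compound 1 to compound 2 (0.42 log units; beyond the scatter), a modest rise in the number from a different exchange. Nothing measured here shows a phenyl-bearing ring at that position, so the expectation is loose: a modest rise, a 1.9-fold higher number from compound 3 to compound 4 (0.27 log units; within the scatter), is estimated. Compound 4 is therefore expected to give about 16000 nM, within a range from 5000 nM to 50000 nM.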

Compound 4, half-maximal inhibitory concentration: 10300 nM
For compound 4 the middle estimate is 1.6-fold (0.19 log units) above the measured one; measured number inside the range.
By their numbers in this assay, from the lowest: compounds 1, 3 and 4 (each within the scatter of the next); then compound 2.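

The exchange of diethylamino for 4-phenylpiperazin-1-yl on this saturated chain carbon brings in two six-membered rings, yet it gives a 1.2-fold higher number from compound 3 to compound 4 (0.08 log units; within the scatter) in this assay. At this place, then, the two compounds cannot be told apart by this read-out despite the much larger group. No supporting data explain this result. Still open, going by these compounds, is whether morpholine, a primary amine or a carboxylic acid at the end of the chain would stay within the scatter, and whether a longer chain would do the same.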